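This account rests on a few compounds, and the source may have more. Where it says the series, first, only, none or still open, it means among the compounds named here.

Measured so far:
compound 1 `COc1ccc(C(=O)Oc2cc3c(cc2C)[C@@H](C(C)C)CC=C3C)cc1` — 37%
compound 2 `COc1cccc(C(=O)Oc2cc3c(cc2C)[C@@H](C(C)C)CC=C3C)c1` — "not active" (no number reported)
compound 3 `Cc1cc2c(C(C)C)ccc(C)c2cc1OC(=O)c1ccc(C(F)(F)F)cc1` — 16.5%

In a functional assay on U-251 cells (Homo sapiens) for antiproliferative activity, read by sulforhodamine B assay, with a stated time of 48 h, tested at 50 uM (a higher number here means more inhibition at the concentration tested (going by the name of the read-out), a lower number less inhibition), compound 1 gives 37%, the highest of the two numbers reported. Compound 3, the nearest entry, sits a margin below it that lies beyond the scatter; for compound 2 no number is given, only that it is not active. Among the compounds with values here, compound 3 also carries a different core from compound 1 and compound 2, so no single step between measured compounds can be read from these three entries.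

Compound 4 `CC1=CC[C@H](C(C)C)c2cc(C)c(OC(=O)c3ccc([N+](=O)[O-])cc3)cc21` is the untested analogue of compound 1. It differs by nitro in place of methoxy on an aromatic carbon.

With no measured step of this kind in the series, the expectation rests on the values of compound 1 and compound 3 alone. Compound 3, which carries a different group in the same position together with a different core, gives 16.5%, a lower number than compound 1. The expected step of a number 9 percentage points lower from compound 1 to compound 4 (within the scatter) is therefore estimated as a modest fall, within or just beyond the scatter. For compound 4 the estimate in this assay is 28%, with a range from 10% to 48%, and some chance that only "not active" is reported.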

Compound 4, a percentage reported as inhibition, at one concentration (the size of the read-out at that concentration, not a potency): 16.8%
Compound 4: middle estimate off by 11.2 percentage points, on the high side; the range from low to high includes it.
By their numbers in this assay, from the lowest: compounds 3 and 4 (each within the scatter of the next); then compound 1.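

In this assay, within the data shown here, the change from 4-methoxyphenyl to 4-nitrophenyl gives the first step that can be read at a single place (a number 20.2 percentage points lower from compound 1 to compound 4 (beyond the scatter)), so the read-out responds to the group on this aromatic carbon, para to a large group. This is one pair on the core of compound 1 and compound 4, and it gives the direction of this one change, not a trend across groups at this position. Nothing measured here accounts for the step.

Open, from the compounds shown here alone, is whether the step follows from losing methoxy or from gaining nitro, and how an amine, a carboxylic acid or a longer alkoxy chain at the same place would read out on this core. Steps involving compound 2 or compound 3 cannot be read, as one has no number and the other differs in more than one place, so the effect of moving the methoxy group and the influence of the core also remain unresolved.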